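A few compounds are considered here, and "the series" means these few. Any claim that something is new, unique, unknown or untested is made for them only; others in the source may bear on it.

Measured compounds:
compound 1 `CC(=O)c1ccc(NC(=O)Nc2cc(C)nc3ccccc23)cc1` — > 25000 nM
compound 2 `Cc1cc(NC(=O)Nc2cc(F)cc(F)c2)c2ccccc2n1` — > 25000 nM
compound 3 `COc1ccccc1NC(=O)Nc1cc(C)nc2ccccc12` — > 25000 nM

In an ADME assay on Raji cells (Homo sapiens) for cytotoxicity, with a stated time of 72 h (a higher number here means that more compound is needed for the effect, a lower number that less compound is needed), none of the three measured compounds gives a number; each value is a limit of the assay. Compound 1 is reported as a limit, > 25000 nM. Compound 2 is likewise only a limit, > 25000 nM. Compound 3 as well comes back as a limit, > 25000 nM. Compound 1 therefore stands exactly where all of the shown values stand, namely at the limit of > 25000 nM in this assay, at which 3 of the 3 values shown sit. Going by the values given here, no step between two measured compounds with a single point of difference is available, so the series gives no measured direction for any change.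

The next compound is compound 4 `Cc1cc(NC(=O)Nc2ccc(N)cc2)c2ccccc2n1`, which differs from compound 1 in one place: amino in place of acetyl on an aromatic carbon. Because compound 1 gives > 25000 nM and that is a limit of the assay, the step from compound 1 to compound 4 is expected to be none beyond the scatter, a step that the limit leaves unreadable from compound 1 to compound 4. Compound 4 is expected at about 30000 nM, within a range from 8000 nM to 100000 nM, and most probably it too will be reported only as a limit.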

Compound 4, half-maximal effective concentration: > 25000 nM
Compound 4 ended at the assay's limit; the forecaster's own chance of this, stated with the estimate: 80%; the middle value lies beyond the limit too.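

No step can be read from compound 1 to compound 4, since both values are limits of the assay: the limit of > 25000 nM in this assay, at which 4 of the 4 values shown sit.

The compounds shown leave open whether any change on the shared core gives a readable number in this assay at all.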